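Removing one ring chlorine from compound 3

This account rests on a few compounds, and the source may have more. Where it says the series, first, only, none or still open, it means among the compounds named here.

Three compounds share one core and differ only in the aryl group on a carbon with a double bond to nitrogen. In a functional assay on HepG2 cells (Homo sapiens) for inhibition, read by MTT assay, with a stated time of 72 h (a higher number here means a weaker inhibitor, a lower number a stronger inhibitor), compound 2 `COc1ccc(/C=N/NC(=O)c2sc(N(C)C(=O)NC(=O)c3c(F)cccc3F)nc2C)cc1` gives 22.7 ug/mL. Compound 3 `Cc1nc(N(C)C(=O)NC(=O)c2c(F)cccc2F)sc1C(=O)N/N=C/c1ccc(Cl)cc1Cl` gives 70 ug/mL, which is a 3.1-fold higher number from compound 2 to compound 3 (0.49 log units; beyond the scatter). Compound 1 `Cc1nc(N(C)C(=O)NC(=O)c2c(F)cccc2F)sc1C(=O)N/N=C/c1ccccc1F` reports only a limit, > 100 ug/mL, sitting at the limit of > 100 ug/mL in this assay, at which 1 of the 3 values shown sits. Of the two numbers shown, compound 3 therefore stands highest, with compound 2 nearest.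

Compound 4 `Cc1nc(N(C)C(=O)NC(=O)c2c(F)cccc2F)sc1C(=O)N/N=C/c1ccccc1Cl` is not yet measured. It differs from compound 3 by hydrogen in place of chloro on an aromatic carbon.

Within the data shown here, no measured step removes a single chloro from this aryl group, so the bearing evidence is indirect. The step from compound 1 to compound 3 exchanges 2-fluorophenyl for 2,4-dichlorophenyl and gives an at least 1.4-fold lower number from compound 1 to compound 3 (0.15 log units; that floor lies within the scatter), a floor that stays within the scatter. Compound 4, with 2-chlorophenyl, sits between those two aryl groups, so the number for compound 4 is expected to lie near that of compound 3 or somewhat higher, with a 1.3-fold higher number from compound 3 to compound 4 (0.11 log units; within the scatter) expected. For compound 4 the estimate is 90 ug/mL, expected to fall between 50 ug/mL and 160 ug/mL.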

Compound 4, half-maximal inhibitory concentration: > 100 ug/mL
Compound 4 was reported as a limit; the forecaster's own chance of this, stated with the estimate: 40%; middle value at least 1.1-fold (0.04 log units) away from the limit.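

In this assay, among these compounds, taking the chloro off this aromatic carbon, para to a large group and meta to a chloro group, gives an at least 1.4-fold higher number from compound 3 to compound 4 (0.15 log units; that floor lies within the scatter), so this first direct reading of the single change shows no shift beyond the scatter, although a floor does not exclude a larger one. The change from 4-methoxyphenyl to 2-chlorophenyl gives an at least 4.4-fold higher number from compound 2 to compound 4 (0.64 log units; beyond the scatter), so the gap seen between compound 2 and compound 3 also holds for this aryl group, and compound 2 keeps the lowest number in the set, with its steps to all three others beyond the scatter. Compound 1 and compound 4 are both reported as limits, and the step between them cannot be read: the limit of > 100 ug/mL in this assay, at which 2 of the 4 values shown sit.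

Among the compounds shown here, how far compound 4 lies past compound 3 remains unknown, since its value is a limit and gives no size for the step. Also open, going by these compounds, is how an amine or a carboxylic acid would read in place of the chloro on this aromatic carbon.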